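Hydroxyphenyl to chlorophenyl on the thiosemicarbazone imine carbon

The compounds below may be only part of what the source reports. "The series", "measured", "known", "first", "only" and "open" are said of these compounds alone.

Compound 2 `CC1=CC[C@H](C(C)(C)NC(=S)N/N=C/c2ccccc2O)CC1` holds the lowest of the two numbers in a functional assay on MCF7 cells (Homo sapiens) for inhibition, read by sulforhodamine B assay, with a stated time of 48 h (on this read-out lower numbers stand for stronger inhibition of growth and higher numbers for weaker inhibition of growth), where compound 2 gives 17500 nM. The unsubstituted hydrazine, compound 1 `CC1=CC[C@H](C(C)(C)NC(=S)NN)CC1`, gives 46700 nM in this assay. Compound 3 `CC1=CC[C@H](C(C)(C)NC(=S)N/N=C/c2ccc(F)cc2)CC1` gives only > 100000 nM in this assay, which is a limit and not a number. That value sits at the limit of > 100000 nM in this assay, at which 1 of the 3 values shown sits. Within the data shown here, the single measured step that bears on the present change is an at least 5.7-fold higher number from compound 2 to compound 3 (0.75 log units; beyond the scatter).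

Compound 4 `CC1=CC[C@H](C(C)(C)NC(=S)N/N=C/c2ccc(Cl)cc2)CC1` differs from compound 2 by 4-chlorophenyl in place of 2-hydroxyphenyl on a carbon with a double bond to nitrogen. With a halogen again in the same ring position, a weakening of similar size to the step toward compound 3 is expected, a 4.6-fold higher number from compound 2 to compound 4 (0.66 log units; beyond the scatter). Compound 4 is therefore estimated at 80000 nM, between 30000 nM and 200000 nM, with a real chance that this assay returns only a limit.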

Compound 4, concentration for total growth inhibition: > 100000 nM
Compound 4 gave a limit, no number; the forecaster's own chance of this, stated with the estimate: 50%; middle value at least 1.2-fold (0.09 log units) from the limit.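

The change to 4-chlorophenyl gives an at least 5.7-fold higher number from compound 2 to compound 4 (0.75 log units; beyond the scatter) and so the loss seen with 4-fluorophenyl no longer rests on fluoro alone. Compound 4 returns a limit in this assay, not a number, and that limit is now shared: the limit of > 100000 nM in this assay, at which 2 of the 4 values shown sit. The step between the two halogen compounds cannot be read, so chloro and fluoro stay unranked.

Left open is whether the hydroxyl itself matters or only the absence of a halogen. An unsubstituted phenyl, or a methoxy group or an amine on that ring, would separate the two.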